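The compounds below may be only part of what the source reports. "The series", "measured", "known", "first", "only" and "open" are said of these compounds alone.

The measured compounds are compound 1, `CC(C)C(NC(=O)c1ccc(C#Cc2ccccc2)cc1)C(=O)NO`, giving 7000 nM, and compound 2, `COCCNC(=O)C[C@H](NC(=O)c1ccc(C#Cc2ccccc2)cc1)C(=O)NO`, giving 78000 nM, both in a physicochemical assay for solubility; a lower number here means a less soluble compound, a higher number a more soluble compound.

Compound 2 stands at the higher of the two numbers, and its gap from compound 1 lies beyond the scatter. Within the data shown here, the two differ in more than one place, so the pair shows only its two values and no single-change step. Compound 3, `NC[C@H](NC(=O)c1ccc(C#Cc2ccccc2)cc1)C(=O)NO`, has not yet been measured in this assay. It differs from compound 2 in one place: amino in place of (2-methoxyethyl)carbamoyl on a saturated chain carbon, two bonds along the chain from an amide-type nitrogen and a carbonyl carbon. Among the measured compounds shown here, no measured pair isolates this change, so the expectation for compound 3 rests on compound 2 and its value 78000 nM. For compound 3 the expected step is a 2.1-fold higher number from compound 2 to compound 3 (0.31 log units; beyond the scatter), a rise rather than nothing beyond the scatter. Compound 3 is thus estimated at 160000 nM, with a range from 40000 nM to 600000 nM.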

Compound 3, solubility: 13000 nM
The estimate for compound 3 lay 12-fold (1.09 log units) above the measured number, and the stated range ends above it.
By their numbers in this assay, from the lowest: compounds 1 and 3 (each within the scatter of the next); then compound 2.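

In this assay, amino in place of (2-methoxyethyl)carbamoyl on this saturated chain carbon gives a 6.0-fold lower number from compound 2 to compound 3 (0.78 log units; beyond the scatter) as a modest step, the first single change seen at this position. It shows that the high number of compound 2 does not survive the loss of that group. The step of a 1.9-fold higher number from compound 1 to compound 3 (0.27 log units; within the scatter) also places compound 3 with compound 1, leaving compound 2 alone at the top of the series. Nothing measured here explains the drop.

The compounds shown leave open whether the step depends on the whole (2-methoxyethyl)carbamoyl group or only on its 2-methoxyethyl part. A plain carbamoyl group or a carboxylic acid on the same carbon would bear on that question.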